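Swapping a ring amine for a flexible basic chain

The source may report more compounds than this note shows. Statements on the series, on what has been measured and on what is new or still open speak of the compounds shown alone.

Within the data shown here, compound 1 `COc1ccc(S(=O)(=O)N2CC(C(=O)NC3CCN(C)CC3)c3ccccc32)c2ccccc12` stands at the lower of the two numbers so far: in a functional assay on CHO cells for antagonist activity at 5-hydroxytryptamine receptor 6 (Homo sapiens), read by FLIPR (on this read-out lower numbers stand for stronger inhibition and higher numbers for weaker inhibition), compound 1 gives 25.1 nM. Compound 2 `COc1ccc(S(=O)(=O)N2CC(C(=O)N3CC(CN)C3)c3ccccc32)c2ccccc12` gives 79.4 nM in this assay. Compound 3 `CCN(CC)CCCNC(=O)C1CN(S(=O)(=O)c2ccc(OC)c3ccccc23)c2ccccc21` differs from compound 1 by 3-(diethylamino)propyl in place of 1-methylpiperidin-4-yl on an amide-type nitrogen. Among the measured compounds shown here, no measured pair makes this exact change; the only step that bears on it, a 3.2-fold higher number from compound 1 to compound 2 (0.50 log units; beyond the scatter), also replaced the amide substituent of compound 1 and was modest and upward. A step of similar size and direction is therefore expected, a 2.0-fold higher number from compound 1 to compound 3 (0.30 log units; within the scatter). Compound 3 is estimated at 50 nM, with a range from 15 nM to 160 nM.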

Compound 3, inhibition constant: 79.4 nM
Estimate against measurement, compound 3: 1.6-fold (0.20 log units) below; low and high end bracket the measured number.
By their numbers in this assay, from the lowest: compound 1; then compounds 2 and 3 (each within the scatter of the next).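

Replacing the 1-methylpiperidin-4-yl ring with the ring-free 3-(diethylamino)propyl chain on the amide-type nitrogen raises the number beyond the scatter (a 3.2-fold higher number from compound 1 to compound 3 (0.50 log units; beyond the scatter)). Compound 2, which carries 3-(aminomethyl)azetidin-1-yl, and compound 3 show no change at the digits printed from compound 2 to compound 3 (within the scatter), so both replacements of the amide substituent of compound 1 end up at the same printed value. Nothing available explains why these groups differ from that of compound 1. Going by these compounds, it remains open whether a shorter chain, such as 2-(diethylamino)ethyl, or a piperazine would bring the number back towards that of compound 1.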